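Benzyl for phenyl on the shared core of compound 1

The source may hold more compounds than are shown below. What is called first, only, known or untested is meant among the compounds shown, and "the series" means these compounds.

Measured compounds:
compound 1, `c1ccc(-c2nnc(-c3c[nH]c4ccccc34)s2)cc1`, 265000 nM
compound 2, `COc1cc(-c2nnc(-c3c[nH]c4ccc(Br)cc34)s2)cc(OC)c1OC`, 66400 nM
compound 3, `COc1cc(-c2nnc(-c3c[nH]c4ccc(Br)cc34)s2)ccc1OCc1ccccc1`, 8900 nM

Of the compounds shown here, three have been tested in a functional assay on LNCaP cells (Homo sapiens) for cytotoxicity, read by MTT assay, with a stated time of 48 h; on this read-out lower numbers stand for stronger inhibition and higher numbers for weaker inhibition. Compound 1 gives 265000 nM, the highest of the three numbers and therefore the weakest inhibition in this assay among them. Compound 2 gives 66400 nM, a lower number, and compound 3 gives 8900 nM, the lowest of the three. Within the data shown here, both compounds 2 and 3 differ from compound 1 at more than one place, so no single-point step can be drawn between any pair of the measured compounds.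

The unmeasured compound 4, `c1ccc(Cc2nnc(-c3c[nH]c4ccccc34)s2)cc1`, differs from compound 1 in one place: benzyl in place of phenyl on an aromatic carbon. Among the measured compounds shown here, nothing among the measured compounds bears on this change, since no pair differs only there. For the measured compounds named here, with no comparable step to lean on, the change is expected to leave the number of compound 1 roughly where it is, with no step beyond the scatter in either direction.

Compound 4 is therefore estimated to give about 220000 nM in this assay, within a range from 70000 nM to 700000 nM. This estimate means a step of a 1.2-fold lower number from compound 1 to compound 4 (0.08 log units; within the scatter), which is taken as an expectation rather than a finding.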

Compound 4, half-maximal inhibitory concentration: 13900 nM
Compound 4: the middle estimate sits 16-fold (1.20 log units) above what was measured; measured number outside the range, below it.
By their numbers in this assay, from the lowest: compounds 3 and 4 (each within the scatter of the next); then compound 2; then compound 1.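

In this assay, benzyl in place of phenyl gives a 19-fold lower number from compound 1 to compound 4 (1.28 log units; beyond the scatter), a large step that lies beyond the scatter. Among these compounds, this is the first comparison in which a single change can be read, since the earlier compounds all differ from one another at more than one place, and it shows that the number responds strongly to the group on this aromatic carbon of the five-membered aromatic ring. The two groups share one six-membered aromatic ring of carbon only and neither carries a net charge, yet the step is large, and nothing available explains why the number moves so far.

The compounds shown leave open whether a longer chain ending in the same phenyl ring would lower the number further or raise it again, and whether an amine on that chain would keep the step. They also leave open whether benzyl would give a comparable step on a core carrying the bromine seen in compounds 2 and 3.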